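The source may hold more compounds than are shown below. What is called first, only, known or untested is meant among the compounds shown, and "the series" means these compounds.

Compound 1 `N=C(N)NS(=O)(=O)c1ccc(N/C(S)=N\c2ccnc3cc(C(F)(F)F)ccc23)cc1` gives 23900 nM in a functional assay on LoVo cells (Homo sapiens) for antiproliferative activity, read by sulforhodamine B assay, with a stated time of 48 h; a higher number here means a weaker inhibitor, a lower number a stronger inhibitor.
Compound 2 `Cc1noc(NS(=O)(=O)c2ccc(N/C(S)=N\c3ccnc4cc(C(F)(F)F)ccc34)cc2)c1C` gives 67100 nM in this assay.
Compound 3 `O=S(=O)(Nc1ccccn1)c1ccc(N/C(S)=N\c2ccnc3cc(C(F)(F)F)ccc23)cc1` gives 87500 nM in this assay.

Compound 3 holds the highest of the three numbers. Its nearest neighbour is compound 2, at a 1.3-fold higher number from compound 2 to compound 3 (0.12 log units; within the scatter), a gap that stays within the scatter, and its furthest is compound 1, at a 3.7-fold higher number from compound 1 to compound 3 (0.56 log units; beyond the scatter). The two steps that leave compound 1, a 2.8-fold higher number from compound 1 to compound 2 (0.45 log units; beyond the scatter) and a 3.7-fold higher number from compound 1 to compound 3 (0.56 log units; beyond the scatter), both go to higher numbers when a ring replaces the open group on the sulfonamide nitrogen.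

Compound 4 `COc1cc(NS(=O)(=O)c2ccc(N/C(S)=N\c3ccnc4cc(C(F)(F)F)ccc34)cc2)nc(OC)n1` differs from compound 3 by 2,6-dimethoxypyrimidin-4-yl in place of pyridin-2-yl on a sulfonamide nitrogen. Among the measured compounds shown here, no measured step swaps one six-membered heteroaryl for another at this position; the closest comparison, a 1.3-fold higher number from compound 2 to compound 3 (0.12 log units; within the scatter), exchanged one aromatic ring for another and stayed within the scatter. On that basis compound 4 is expected to sit close to compound 3, with the step of a 1.1-fold lower number from compound 3 to compound 4 (0.04 log units; within the scatter) not clearly beyond the scatter. The estimate for compound 4 is therefore 80000 nM, within a range of 30000 nM to 200000 nM.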

Compound 4, half-maximal inhibitory concentration: 76700 nM
Compound 4: the middle estimate sits 1.0-fold (0.02 log units) above what was measured; the measured number falls inside the stated range.
By their numbers in this assay, from the lowest: compound 1; then compounds 2, 4 and 3 (each within the scatter of the next).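

Among the compounds shown here, in (this assay), 2,6-dimethoxypyrimidin-4-yl on the sulfonamide nitrogen gives the first exchange of one six-membered aromatic ring for another at this position, and the step (a 1.1-fold lower number from compound 3 to compound 4 (0.06 log units; within the scatter)) stays within the scatter. The step from the five-membered ring (a 1.1-fold higher number from compound 2 to compound 4 (0.06 log units; within the scatter)) also stays within the scatter, so compounds 2, 3 and 4 cannot be told apart here, even though their ring groups differ in size, ring hetero atoms and hydrogen-bond acceptors. The gap to the open group persists with this larger ring (a 3.2-fold higher number from compound 1 to compound 4 (0.51 log units; beyond the scatter)), and all three ring-bearing compounds give higher numbers than compound 1.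

Nothing available explains this gap. As far as these compounds go, it remains open whether an acetyl group or a saturated piperidine ring on the sulfonamide nitrogen would fall with compound 1 or with the aromatic ring compounds.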